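From fluoro to ethyl: one small change on compound 2

The compounds below may be only part of what the source reports. "The series", "measured", "known", "first", "only" and "open" are said of these compounds alone.

Of the compounds shown here, two have so far been measured in a functional assay on CHO cells for agonist activity at Glucose-dependent insulinotropic receptor (Homo sapiens), read by cAMP accumulation; a lower number here means that less compound is needed, a higher number that more compound is needed for the effect. Compound 1 `CCOc1cnc(N2CCC([C@H]3C[C@H]3COCc3ccc(S(C)(=O)=O)c(F)c3)CC2)nc1` carries an ethoxy group on an aromatic carbon of the shared core, and in this assay compound 1 gives 1.7 nM. Compound 2 `CS(=O)(=O)c1ccc(COC[C@@H]2C[C@@H]2C2CCN(c3ncc(F)cn3)CC2)cc1F` differs from it only at that carbon, and in this assay compound 2 gives 2.4 nM. The step of a 1.4-fold higher number from compound 1 to compound 2 (0.15 log units; within the scatter) is no larger than the usual spread of repeated measurements, so the two numbers should be read as the same. Compound 2 thus holds the higher of the two numbers, but only by a margin that carries no meaning.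

Compound 3 `CCc1cnc(N2CCC([C@H]3C[C@H]3COCc3ccc(S(C)(=O)=O)c(F)c3)CC2)nc1` has not yet been measured. It differs from compound 2 in this way: ethyl in place of fluoro on an aromatic carbon. For the measured compounds named here, the one step that bears on this place, a 1.4-fold higher number from compound 1 to compound 2 (0.15 log units; within the scatter), shows that swapping a small group for a larger oxygen-linked group there changed little. An ethyl group is again a small carbon group at the same place, so no step beyond the scatter is expected in this assay, in either direction; the expected step is a 1.2-fold lower number from compound 2 to compound 3 (0.08 log units; within the scatter). Compound 3 is therefore estimated at about 2 nM, with a likely range from 0.8 nM to 5 nM.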

Compound 3, half-maximal effective concentration in the Glucose-dependent insulinotropic receptor assay: 2.5 nM
Compound 3: the middle estimate sits 1.3-fold (0.10 log units) below what was measured; the measured number falls inside the stated range.
By their numbers in the Glucose-dependent insulinotropic receptor assay, from the lowest: compounds 1, 2 and 3 (each within the scatter of the next).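

In the Glucose-dependent insulinotropic receptor assay, compound 1 gives 1.7 nM, compound 2 gives 2.4 nM and compound 3 gives 2.5 nM; ethyl in place of fluoro gives a 1.0-fold higher number from compound 2 to compound 3 (0.02 log units; within the scatter), and ethyl in place of ethoxy gives a 1.5-fold higher number from compound 1 to compound 3 (0.17 log units; within the scatter), so all three groups at this place on the six-membered aromatic ring read as one result. The earlier pair could not show whether the oxygen of the ethoxy group was needed to match fluoro here; ethyl carries no oxygen and no fluorine, only 2 carbon atoms, and the number in this assay still does not move beyond the scatter. In a physicochemical assay for lipophilicity, read by HPLC, at pH 7 (a higher number here means a more lipophilic compound, a lower number a more polar compound), compound 2 gives 4.2 and compound 3 gives 4.3; the same change from fluoro to ethyl gives a number 0.10 log units higher from compound 2 to compound 3 (within the scatter), so the physicochemical assay separates the 5-fluoropyrimidin-2-yl and 5-ethylpyrimidin-2-yl compounds no better than the Glucose-dependent insulinotropic receptor assay does.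

The compounds shown leave open how far this tolerance extends, since none of them carries a longer chain, an added ring, an amine or a carboxylic acid at this carbon, and any of these might give a step beyond the scatter. No measurement here offers an explanation of why these three groups read alike.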